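Removing the benzyl group from an anilino nitrogen

This account rests on a few compounds, and the source may have more. Where it says the series, first, only, none or still open, it means among the compounds named here.

Measured so far:
compound 1, `COc1ccc(C(=O)Nc2cccc3c2N(S(=O)(=O)c2ccc(OC)cc2)CC3)cc1`, 2600 nM
compound 2, `COc1ccc(S(=O)(=O)N2CCc3cccc(NCc4ccccc4)c32)cc1`, > 10000 nM

Compound 1 is the only one of the two with a numbered result in a functional assay on KB cells (Homo sapiens) for cytotoxicity (a higher number here means a weaker inhibitor, a lower number a stronger inhibitor), where compound 1 gives 2600 nM. For compound 2 this assay reports only a limit, > 10000 nM, so compound 2 sits at the weak end of what the measurement can resolve (the limit of > 10000 nM in this assay, at which 1 of the 2 values shown sits).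

The unmeasured compound 3, `COc1ccc(S(=O)(=O)N2CCc3cccc(N)c32)cc1`, differs from compound 2 in one place: hydrogen in place of benzyl on a nitrogen on an aromatic ring. Benzylamino becomes amino.

Within the data shown here, only one measured step exists, an at least 3.8-fold higher number from compound 1 to compound 2 (0.58 log units; beyond the scatter), and it concerns the group that compound 3 now loses entirely rather than the change from benzyl to hydrogen itself. It therefore does not tell which way this step should run. With compound 2 already at the limit, the expected step that the limit leaves unreadable from compound 2 to compound 3 is small and uncertain in direction, and compound 3 is estimated at 15000 nM, within 4000 nM to 50000 nM.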

Compound 3, half-maximal inhibitory concentration: 2800 nM
Beside the measured number, compound 3's estimate is 5.4-fold (0.73 log units) above it; the whole stated range lies above it.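

Taking the benzyl group off this nitrogen on an aromatic ring gives an at least 3.5-fold lower number from compound 2 to compound 3 (0.55 log units; beyond the scatter) in this assay, so the drop in activity seen earlier comes with benzyl itself and not with any change away from the (4-methoxyphenyl)carbonyl group. Replacing (4-methoxyphenyl)carbonyl with hydrogen gives a 1.1-fold higher number from compound 1 to compound 3 (0.03 log units; within the scatter), so in this pair that group neither adds to nor takes from the activity of the plain amino compound by more than the scatter. As far as these compounds go, the real size of the benzyl step stays unknown because compound 2 gives only a limit: the limit of > 10000 nM in this assay, at which 1 of the 3 values shown sits.

The compounds shown leave open whether a small group on this nitrogen, such as methyl or acetyl, would behave like hydrogen or like benzyl. They also leave open whether a two-carbon phenylethyl chain there would match benzyl.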